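Cytotoxicity notes on an arylidene amidrazone series

The source may report more compounds than this note shows. Statements on the series, on what has been measured and on what is new or still open speak of the compounds shown alone.

Measured compounds:
compound 1, `N/C(CC(O)c1cccc2ccccc12)=N\N=C\c1ccc(Cl)c(Cl)c1`: 16000 nM
compound 2, `CCOc1cc(/C=N/N=C(\N)CC(O)c2ccc3ccccc3c2)ccc1O`: 78000 nM

In an ADME assay on L6 cells (Rattus norvegicus) for cytotoxicity, read by resazurin assay, with a stated time of 72 h (on this read-out higher numbers stand for weaker inhibition and lower numbers for stronger inhibition), compound 1 gives 16000 nM. In this assay compound 2 gives 78000 nM. Compound 1 thus holds the lower of the two numbers, and the gap to compound 2 lies beyond the usual scatter, so compound 1 is the stronger inhibitor of the pair on this read-out. Among the compounds with values here, no step between a pair of measured compounds that differ in only one place is available, so the series gives no direct precedent for a single change on the aryl group.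

Compound 3, `N/C(CC(O)c1cccc2ccccc12)=N\N=C\c1ccccc1`, has not yet been measured in this assay. It differs from compound 1 in one place: phenyl in place of 3,4-dichlorophenyl on a carbon with a double bond to nitrogen. Within the data shown here, with only two measured numbers to go on, the expectation is a modest rise in the number, that is weaker inhibition, with a step of a 2.2-fold higher number from compound 1 to compound 3 (0.34 log units; beyond the scatter) expected, though a result within the scatter of compound 1 would not surprise. For compound 3 the expected value is 35000 nM, with a range from 12000 nM to 120000 nM.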

Compound 3, half-maximal inhibitory concentration: 17000 nM
The estimate for compound 3 lay 2.1-fold (0.31 log units) above the measured number; the range from low to high includes it.
By their numbers in this assay, from the lowest: compounds 1 and 3 (each within the scatter of the next); then compound 2.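

In this assay, within the data shown here, phenyl in place of 3,4-dichlorophenyl on a carbon with a double bond to nitrogen gives a 1.1-fold higher number from compound 1 to compound 3 (0.03 log units; within the scatter) and so provides the only single-place step available. At this position, on the core of compound 1, loss of both chlorine atoms therefore leaves the cytotoxicity read-out within the usual scatter, so for this pair the chlorine atoms are not needed to keep the number where it stands. Nothing at hand explains why the read-out stays within the scatter for this change.

On these data alone, whether the same holds for other groups at this position remains open, for example a phenyl ring carrying an amine or a carboxylic acid, or a pyridine ring in place of the phenyl. The step also does not show which differences set compound 2 apart, since that compound differs from compound 1 and compound 3 in more than one place.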